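A Methyl Takes the Place of a Methoxy

The compounds below may be only part of what the source reports. "The series", "measured", "known", "first", "only" and "open" are said of these compounds alone.

Measured so far in a functional assay on PANC-1 cells (Homo sapiens) for cytotoxicity, read by MTT assay, with a stated time of 72 h, tested at 1 uM; on this read-out higher numbers stand for a weaker effect at the one concentration tested and lower numbers for a stronger effect:
- compound 1 `C=C1C(=O)O[C@H](c2ccccc2)[C@H]1c1ccccc1`: 116%
- compound 2 `C=C1C(=O)O[C@H](c2ccc(OC)cc2)[C@H]1c1ccccc1`: 80%

Going by the values given here, compound 2 holds the lowest of the two numbers so far; its nearest neighbour is compound 1, and the single measured step, a number 36 percentage points lower from compound 1 to compound 2 (beyond the scatter), lies beyond the scatter. Among the compounds with values here, that step is the only guide available, and it concerns a methoxy entering where hydrogen stood, not an exchange of one group for another.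

Compound 3 `C=C1C(=O)O[C@H](c2ccc(C)cc2)[C@H]1c1ccccc1` differs from compound 2 in one place: methyl in place of methoxy on an aromatic carbon. Within the data shown here, no measured step swaps methoxy for methyl, so the direction of the change cannot be read from the numbers. The step from compound 1 to compound 2 shows that a group at this place can move the read-out markedly, which argues against assuming no change at all, yet gives no sign either way. Compound 3 is therefore expected to sit near compound 2, with a step of a number 12 percentage points higher from compound 2 to compound 3 (beyond the scatter), and its estimated value is 92%, in a range from 68% to 118%.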

Compound 3, a percentage reported as activity, at one concentration (the size of the read-out at that concentration, not a potency): 105%
The estimate for compound 3 lay 13 percentage points below the measured number; measured number inside the range.
By their numbers in this assay, from the lowest: compound 2; then compound 3; then compound 1.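

In this assay, this position responds not only to whether a group is present but also to which group it is: methyl in place of methoxy gives a number 25 percentage points higher from compound 2 to compound 3 (beyond the scatter), so the two are not interchangeable here. Methyl in place of hydrogen still gives a number 11 percentage points lower from compound 1 to compound 3 (beyond the scatter), the same direction as methoxy but a smaller step than a number 36 percentage points lower from compound 1 to compound 2 (beyond the scatter), so among these three compounds hydrogen, methyl and methoxy form a graded series. Nothing available explains this difference between methyl and methoxy.

Open, going by these compounds, is how other groups at this place would fit into that series, such as a chlorine atom, an amine or a longer chain like ethoxy. Also open, on these data alone, is whether the same order would hold at other concentrations, since each compound is represented by a single one.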